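Hydroxymethyl Gives Way to a Carbamoyl Group

The compounds below may be only part of what the source reports. "The series", "measured", "known", "first", "only" and "open" are said of these compounds alone.

In a functional assay on OVCAR-8 cells (Homo sapiens) for antiproliferative activity (a lower number here means a stronger inhibitor, a higher number a weaker inhibitor), compound 2 (`Cn1ncc(Cl)c1-c1cc(C(=O)N[C@@H]2CN[C@H](CCO)C[C@H]2c2ccc(Cl)c(Cl)c2)oc1Cl`) is the stronger of the two measured compounds at 610 nM, while compound 1 (`Cn1ncc(Cl)c1-c1cc(C(=O)N[C@@H]2CN[C@H](CC(=O)NCC(O)CO)C[C@H]2c2ccc(Cl)c(Cl)c2)oc1Cl`) gives 5900 nM. Compound 3 (`Cn1ncc(Cl)c1-c1cc(C(=O)N[C@@H]2CN[C@H](CC(=O)NCCO)C[C@H]2c2ccc(Cl)c(Cl)c2)oc1Cl`) carries (2-hydroxyethyl)carbamoyl in place of hydroxymethyl on a saturated chain carbon bound to a saturated ring carbon. For the measured compounds named here, the one relevant measured change, a 9.7-fold lower number from compound 1 to compound 2 (0.99 log units; beyond the scatter), put hydroxymethyl in place of (2,3-dihydroxypropyl)carbamoyl. The new change runs the opposite way with a similar group, so a somewhat smaller rise is expected, estimated as a 4.9-fold higher number from compound 2 to compound 3 (0.69 log units; beyond the scatter). Compound 3 is expected at 3000 nM, with an estimated range of 1000 nM to 8000 nM.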

Compound 3, half-maximal inhibitory concentration: 1450 nM
Compound 3: middle estimate off by 2.1-fold (0.32 log units), on the high side, and the stated range covers the measured number.
By their numbers in this assay, from the lowest: compound 2; then compound 3; then compound 1.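

In this assay, (2-hydroxyethyl)carbamoyl at this saturated chain carbon still gives a weaker result than hydroxymethyl (a 2.4-fold higher number from compound 2 to compound 3 (0.38 log units; beyond the scatter)), so the drop is not confined to the larger (2,3-dihydroxypropyl)carbamoyl group. Losing the hydroxymethyl at the end of that larger group recovers part of the drop (a 4.1-fold lower number from compound 1 to compound 3 (0.61 log units; beyond the scatter)), showing that the end of the chain also affects the number. No evidence here explains either step.

The effect of the carbamoyl link itself remains separate from that of chain length. From the compounds shown here alone, a terminal amine or carboxylic acid on this chain also remains untested in these compounds.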